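The source may report more compounds than this note shows. Statements on the series, on what has been measured and on what is new or still open speak of the compounds shown alone.

Measured compounds:
compound 1, `O=C(Cn1c(=O)c(Cc2ccccc2)nc2ccccc21)NNC(=S)Nc1ccccc1`: 5.41 nM
compound 2, `C(=N/NC1Nc2ccccc2N=C1Cc1ccccc1)\c1ccccc1`: 81 nM

Of the compounds shown here, two have so far been measured in an assay on isolated protein for inhibition of Amine oxidase [flavin-containing] A (Homo sapiens), read by spectrophotometry; a higher number here means a weaker inhibitor, a lower number a stronger inhibitor. Compound 1 stands at the lowest number of the pair, and compound 2 sits well above it, a gap that lies beyond the usual scatter of this assay. The unmeasured compound 3 (`Cc1ccc(C(=O)NNC(=O)Cn2c(=O)c(Cc3ccccc3)nc3ccccc32)cc1`) is derived from compound 1 by the change (a group of 9 heavy atoms (8 carbon, 1 oxygen; one six-membered aromatic ring of carbon only) in place of a group of 9 heavy atoms (7 carbon, 1 nitrogen, 1 sulfur; one six-membered aromatic ring of carbon only), on an amine nitrogen). Among the compounds with values here, no step between the two measured compounds matches this change, so there is nothing in the measured pair to calibrate it against, and the expectation rests on the standing of compound 1 alone. For compound 3 the expected step in this assay is a 3.7-fold higher number from compound 1 to compound 3 (0.57 log units; beyond the scatter), a modest move toward a weaker inhibitor, with considerable uncertainty in both directions. Compound 3 is accordingly estimated at 20 nM, within a range from 4 nM to 100 nM.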

Compound 3, half-maximal inhibitory concentration: 5.33 nM
For compound 3 the middle estimate is 3.8-fold (0.57 log units) above the measured one; measured number inside the range.
By their numbers in this assay, from the lowest: compounds 3 and 1 (each within the scatter of the next); then compound 2.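

In this assay the step of a 1.0-fold lower number from compound 1 to compound 3 (0.01 log units; within the scatter) shows that this position, an amine nitrogen whose other neighbours are an amide-type nitrogen, tolerates a real change of group without a change beyond the scatter. The entering (4-methylphenyl)carbonyl carries no nitrogen, sulfur or hydrogen-bond donor, whereas the group that leaves has all three, so none of these features of the leaving group is required to hold the number at this level. Nothing measured here explains why the two groups read alike.

On these data alone, it remains open whether the six-membered aromatic ring that both groups carry is needed at all, which a plain acetyl group on this nitrogen would test. Also open, as far as these compounds go, is whether the methyl of (4-methylphenyl)carbonyl contributes anything, and how a carboxylic acid or an amine on that ring would read.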